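Trifluoromethyl in place of chloro on the shared core

A few compounds are considered here, and "the series" means these few. Any claim that something is new, unique, unknown or untested is made for them only; others in the source may bear on it.

Values so far in a functional assay on A549 cells (Homo sapiens) for antiproliferative activity, read by MTT assay, with a stated time of 48 h; on this read-out lower numbers stand for stronger inhibition and higher numbers for weaker inhibition
compound 1 `FC(F)(F)c1ccc2[nH]c(-c3cn(-c4ccccc4)nc3-c3ccccc3)nc2c1` gives 5930 nM
compound 2 `Fc1ccc2[nH]c(-c3cn(-c4ccccc4)nc3-c3ccc(Cl)cc3)nc2c1` gives 4610 nM
compound 3 `Clc1ccc(-c2nn(-c3ccccc3)cc2-c2nc3cc(Cl)ccc3[nH]2)cc1` gives 1340 nM

Compound 3 has the lowest of the three numbers in this assay and lies beyond the scatter from both other compounds. Still unmeasured is compound 4 `FC(F)(F)c1ccc2[nH]c(-c3cn(-c4ccccc4)nc3-c3ccc(Cl)cc3)nc2c1` with the change trifluoromethyl in place of chloro on an aromatic carbon. Within the data shown here, the one measured step at this carbon is a 3.4-fold lower number from compound 2 to compound 3 (0.54 log units; beyond the scatter) (chloro in place of fluoro). It is modest and beyond the scatter, but it does not involve trifluoromethyl, so it gives no direct size for the new change. Among the measured compounds shown here, compound 1 is the only measured compound with trifluoromethyl and gives 5930 nM in this assay, yet it differs from compound 3 in more than one place and is only a weak guide. A small upward shift within the scatter is therefore expected, and the estimated step is a 1.5-fold higher number from compound 3 to compound 4 (0.17 log units; within the scatter) in this assay as a working figure. Compound 4 is estimated at 2000 nM (expected range 700 nM to 5000 nM)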

Compound 4, half-maximal inhibitory concentration: 3360 nM
Estimate against measurement, compound 4: 1.7-fold (0.23 log units) below; measured number inside the range.
By their numbers in this assay, from the lowest: compound 3; then compounds 4, 2 and 1 (each within the scatter of the next).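

In this assay, the step of a 2.5-fold higher number from compound 3 to compound 4 (0.40 log units; beyond the scatter) shows that trifluoromethyl does not keep the lower number seen with chloro on this aromatic carbon, while a 1.4-fold lower number from compound 2 to compound 4 (0.14 log units; within the scatter) leaves trifluoromethyl and fluoro within the scatter of each other. Among compounds 2, 3 and 4, chloro alone therefore stands apart at this carbon, and no compound among these three goes against that reading. The step of a 1.8-fold lower number from compound 1 to compound 4 (0.25 log units; within the scatter) gives the first read on chloro in place of hydrogen at the second varied place, and with trifluoromethyl on the core it stays within the scatter; nothing available explains either result.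

Going by these compounds, whether that second change would also stay within the scatter with chloro on the core remains open. Also open, on these data alone, is how an amine or a methoxy group on this aromatic carbon would compare with chloro.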